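Aryl-thiazole ethers on a shared acid core: activity at one concentration

This account rests on a few compounds, and the source may have more. Where it says the series, first, only, none or still open, it means among the compounds named here.

Measured compounds:
compound 1, `O=C(O)CC1COc2cc(OCc3nnc(-c4ccccc4)o3)ccc21`, 1.54%
compound 2, `O=C(O)CC1COc2cc(OCc3ncc(-c4ccccc4)s3)ccc21`, 5.26%
compound 3, `Cc1nc(-c2cccc3ccccc23)sc1COc1ccc2c(c1)OCC2CC(=O)O`, 8.53%

All three share the same acid-bearing core and differ in the aromatic ether that hangs from it. In a functional assay on CHO cells for agonist activity at Free fatty acid receptor 1 (Homo sapiens), read by FLIPR and calcium flux, tested at 100 nM (a lower number here means a weaker effect, a higher number a stronger effect of the compound at the concentration tested), compound 1 gives 1.54%, compound 2 gives 5.26% and compound 3 gives 8.53%. Compound 3 holds the highest of the three numbers, but its gap to compound 2 and its gap to compound 1 both lie within the scatter, so the three cannot be told apart on these readings. Going by the values given here, no step between two measured compounds that differ in a single place is available, so nothing is known here about how a single change moves the number.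

Compound 4, `Cc1nc(-c2ccc(Cl)cc2)sc1COc1ccc2c(c1)OCC2CC(=O)O`, is not yet measured. It differs from compound 3 in one place: 4-chlorophenyl in place of naphthalen-1-yl on an aromatic carbon. Among the compounds with values here, with no single-place step to lean on and all three known numbers within the scatter of one another, the expected step from compound 3 to compound 4 is a number 1.5 percentage points lower from compound 3 to compound 4 (within the scatter), that is, none beyond the scatter in either direction. Compound 4 is therefore expected to give about 7% in this assay, with a range from 0% to 22%.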

Compound 4, a percentage reported as activity, at one concentration (the size of the read-out at that concentration, not a potency): 53.4%
Beside the measured number, compound 4's estimate is 46.4 percentage points below it; the whole stated range lies below it.
By their numbers in this assay, from the lowest: compounds 1, 2 and 3 (each within the scatter of the next); then compound 4.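

In this assay the step of a number 44.9 percentage points higher from compound 3 to compound 4 (beyond the scatter) shows that the aryl group on this aromatic carbon of the five-membered aromatic ring with 1 nitrogen and 1 sulfur is a place where a single change can move the read-out well beyond the scatter. Going by these compounds alone, the earlier compounds offered only readings within the scatter of one another and no single-place step, so this is the first indication that the series responds to a change here, with 4-chlorophenyl, of 7 heavy atoms and one six-membered aromatic ring, standing in place of naphthalen-1-yl, of 10 heavy atoms and 2 such rings. Nothing measured here explains the step, and it cannot be assigned to the chlorine, to the single ring or to the lower heavy-atom count.

Plain phenyl on this same methyl-bearing ring would separate the contribution of the chlorine from that of the change in ring count. As far as these compounds go, it also remains open whether 4-fluorophenyl, 4-methoxyphenyl or 4-(trifluoromethyl)phenyl would hold the read-out at this level, and whether the step survives replacing the methyl group with an ethyl group.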